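A few compounds are considered here, and "the series" means these few. Any claim that something is new, unique, unknown or untested is made for them only; others in the source may bear on it.

Compound 1 `COc1ccc(C(=O)/C=C/c2cc(-c3cc(OC)c(OC)c(OC)c3)n[nH]2)cc1OC` gives 1630 nM in a functional assay on T47D cells (Homo sapiens) for inhibition, read by sulforhodamine B assay, with a stated time of 48 h (a lower number here means a stronger inhibitor of growth, a higher number a weaker inhibitor of growth), and compound 2 `COc1ccc(C(=O)/C=C/c2cc(-c3cc(OC)c(OC)c(OC)c3)n[nH]2)cc1` gives 2310 nM in this assay. Among the compounds with values here, the single measured step, a 1.4-fold higher number from compound 1 to compound 2 (0.15 log units; within the scatter), stays within the scatter, so compound 2 stands alongside compound 1 with nothing separating them. Compound 3 `COc1cc(-c2cc(/C=C/C(=O)c3ccc(F)c(F)c3)[nH]n2)cc(OC)c1OC` carries 3,4-difluorophenyl in place of 4-methoxyphenyl on a carbonyl carbon. Within the data shown here, only the step from compound 1 to compound 2 touches this ring, and it was within the scatter; no measured step covers fluorine. For compound 3 the expected step is a 1.2-fold higher number from compound 2 to compound 3 (0.08 log units; within the scatter), not beyond the scatter. The estimate for compound 3 in this assay is 2800 nM, within 1000 nM to 8000 nM.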

Compound 3, concentration for 50% growth inhibition: 2450 nM
Compound 3: middle estimate off by 1.1-fold (0.06 log units), on the high side; measured number inside the range.
By their numbers in this assay, from the lowest: compounds 1, 2 and 3 (each within the scatter of the next).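

In this assay the carbonyl carbon accepts 3,4-difluorophenyl: replacing 4-methoxyphenyl gives a 1.1-fold higher number from compound 2 to compound 3 (0.03 log units; within the scatter) and replacing 3,4-dimethoxyphenyl gives a 1.5-fold higher number from compound 1 to compound 3 (0.18 log units; within the scatter) so methoxy on this ring is not required for the growth inhibition seen in these three compounds. Unlike the earlier step, these two replace the methoxy pattern entirely, and compounds 1, 2 and 3 still cannot be told apart. Nothing measured here accounts for this.

Still open, from the compounds shown here alone, is whether any group at this position separates from the scatter, for instance an amine or a carboxylic acid on the ring. Also open, going by these compounds, is whether a longer chain in place of the aryl ring would do so.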